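Replacing cyclohexyl with hex-1-yn-1-yl

The source may hold more compounds than are shown below. What is called first, only, known or untested is meant among the compounds shown, and "the series" means these compounds.

- compound 1 `Cc1[nH]c2ccccc2c(=O)c1C1CCCCC1`: 2.45
- compound 2 `CCCCCC/C=C\Cc1c(C)[nH]c2ccccc2c1=O`: 5.94

In a physicochemical assay for lipophilicity, at pH 7.4 (a higher number here means a more lipophilic compound, a lower number a more polar compound), compound 1 at 2.45 is the lower of the two, and compound 2 reads 5.94. The gap between these two compounds lies well beyond the scatter. Compound 3 `CCCCC#Cc1c(C)[nH]c2ccccc2c1=O` carries hex-1-yn-1-yl in place of cyclohexyl on an aromatic carbon. For the measured compounds named here, no measured pair shows this exact change, so any forecast is uncertain. Compound 2 also has an open chain and no ring there, and it reads 5.94, so a moderate rise beyond the scatter is expected. The estimated change is a number 1.15 log units higher from compound 1 to compound 3 (beyond the scatter). For compound 3 the expected value is 3.6, with an estimated range of 2.8 to 4.5.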

Compound 3, distribution coefficient: 5.44
Compound 3: middle estimate off by 1.84 log units, on the low side, outside the stated range (above it).
By their numbers in this assay, from the lowest: compound 1; then compound 3; then compound 2.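

In this assay, putting hex-1-yn-1-yl in place of cyclohexyl on this aromatic carbon gives a large step, a number 2.99 log units higher from compound 1 to compound 3 (beyond the scatter), beyond the scatter. Both groups have 6 heavy atoms, so at this position the reading can shift strongly even when the heavy-atom count stays the same. No measurement shown here accounts for the size of this step.

A plain hexyl chain at this position would separate the effect of the triple bond from that of opening the ring. Going by these compounds, how an amine or a carboxylic acid would read here remains open.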